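Swapping phenyl for furan-2-yl on a weak arylamine

The source may report more compounds than this note shows. Statements on the series, on what has been measured and on what is new or still open speak of the compounds shown alone.

Compound 1 `N#Cc1ccc(N2CCCc3c(-c4cccnc4)cccc32)cc1C(F)(F)F`: in a functional assay on CWR22R cells (Homo sapiens) for antiproliferative activity, read by CCK-8 assay, with a stated time of 6 days (on this read-out lower numbers stand for stronger inhibition and higher numbers for weaker inhibition), compound 1 gives 12300 nM.
Compound 2 `Cc1noc(C)c1-c1cccc(Oc2ccc(C#N)c(C(F)(F)F)c2)c1`: in this assay compound 2 carries the entry "not determined" (no result reported), so no result was reported for compound 2.
Compound 3 `CCN(c1ccc(C#N)c(Cl)c1)c1cc(-c2ccccc2)ccc1C`: in this assay compound 3 reaches only the limit of > 30000 nM.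

Among these three, compound 3 has no single number of its own: its entry is a limit, meaning the assay did not resolve a value, and it sits at the limit of > 30000 nM in this assay, at which 1 of the 3 values shown sits. Within the data shown here, the one compound with a measured number, compound 1, carries a different core, so its value cannot be put beside compound 3 as a step; only compound 1 shows how far above the limit a measured number can lie.

Compound 4 `CCN(c1ccc(C#N)c(Cl)c1)c1cc(-c2ccco2)ccc1C` is the next member, and it differs from compound 3 in one place: furan-2-yl in place of phenyl on an aromatic carbon. Among the measured compounds shown here, no step between two measured compounds is available to size this change, and the starting point is itself a limit. The reasonable expectation is therefore a change of no more than the usual scatter, with no clear direction, so compound 4 is expected to remain close to the limit. The step from compound 3 to compound 4 is estimated as a number no higher from compound 3 to compound 4 (the limit leaves the size open). Compound 4 is estimated at 30000 nM, within a range from 8000 nM to 100000 nM.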

Compound 4, half-maximal inhibitory concentration: > 30000 nM
Compound 4 ended at the assay's limit (the forecaster's own chance of this, stated with the estimate: 60%); the middle value lies on the limit itself.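

Among these compounds, compound 3 and compound 4 both rest on a limit rather than a number, so the change from phenyl to furan-2-yl gives no step that can be read: the limit of > 30000 nM in this assay, at which 2 of the 4 values shown sit. The compounds shown leave open whether furan-2-yl and phenyl differ at all in this assay and by how much.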